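Swapping chloro for sulfamoyl in compound 2's core

This account rests on a few compounds, and the source may have more. Where it says the series, first, only, none or still open, it means among the compounds named here.

Compound 2 `COc1ccc(-c2nn(-c3ccc(Cl)cc3)cc2C(CC(=O)c2ccc(Cl)cc2)C(=O)c2ccc(F)cc2)cc1` is one of three compounds tested in a functional assay on the whole organism (strain Wistar albino) for inhibition, with Rattus norvegicus as the target, read by paw edema, with stated times of 1 h and 2 h, at a dose of 0.32 mmol/kg by the intraperitoneal route; a lower number here means less inhibition, a higher number more inhibition at the dose given (going by the name of the read-out). Its neighbours are compound 1 `Cc1ccc(-c2nn(-c3ccc(Cl)cc3)cc2C(CC(=O)c2ccc(Cl)cc2)C(=O)c2ccc(F)cc2)cc1` and compound 3 `COc1ccc(C(=O)C(CC(=O)c2ccc(Cl)cc2)c2cn(-c3ccc(Cl)cc3)nc2-c2ccc(OC)cc2)cc1`. In this assay compound 1 gives 25.9%, compound 2 gives 19.8% and compound 3 gives 0%. Compound 2 thus stands second highest of the three, with compound 1 within the scatter of it and compound 3 beyond it. The step of a number 6.1 percentage points lower from compound 1 to compound 2 (within the scatter) is small, whereas the step of a number 19.8 percentage points lower from compound 2 to compound 3 (beyond the scatter) is modest.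

Compound 4 `COc1ccc(-c2nn(-c3ccc(S(N)(=O)=O)cc3)cc2C(CC(=O)c2ccc(Cl)cc2)C(=O)c2ccc(F)cc2)cc1` differs from compound 2 in one place: sulfamoyl in place of chloro on an aromatic carbon. For the measured compounds named here, neither measured step changes this position on the shared core, so no step bears directly on it; both show that a single change at an aromatic carbon can leave the read-out within the scatter or lower it modestly. Compound 4 is therefore expected to give 26% in this assay, within a range of 10% to 42%. The expected step of a number 6.2 percentage points higher from compound 2 to compound 4 (within the scatter) is estimated to stay within the scatter.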

Compound 4, a percentage reported as inhibition, in the whole organism at one dose (the size of the read-out at that dose, not a potency): 72.2%
Beside the measured number, compound 4's estimate is 46.2 percentage points below it, and the stated range ends below it.
By their numbers in this assay, from the lowest: compound 3; then compounds 2 and 1 (each within the scatter of the next); then compound 4.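

In this assay, the place on the 4-chlorophenyl group, which neither earlier step touched, proves able to move the read-out strongly: the change to 4-sulfamoylphenyl gives a number 52.4 percentage points higher from compound 2 to compound 4 (beyond the scatter). The earlier steps, both made elsewhere on the shared core, left the number within the scatter or lowered it, so this is the first single change shown that raises it beyond the scatter. Nothing available explains why this swap has such an effect on paw edema inhibition.

From the compounds shown here alone, whether a methylsulfonyl group or a carboxylic acid at this same place would give a similar step remains open. Going by these compounds, it is also open whether sulfamoyl in place of chloro would raise the number to a similar extent on the core of compound 1 or of compound 3.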